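Removing an amino group from a shared core

The source may hold more compounds than are shown below. What is called first, only, known or untested is meant among the compounds shown, and "the series" means these compounds.

Three compounds have been measured in a functional assay on HT-29 cells (Homo sapiens) for cytotoxicity, read by sulforhodamine B assay, with a stated time of 48 h; on this read-out lower numbers stand for higher toxicity in this test and higher numbers for lower toxicity in this test:

compound 1, `ClCc1cccc(Cn2cnc3c(Cl)nc(Cl)nc32)c1`, sits at the limit of the test, > 100000 nM
compound 2, `Nc1nc(Cl)c2ncn(Cc3ccccc3CCl)c2n1`, sits at the limit of the test, > 100000 nM
compound 3, `ClCc1ccccc1Cn1cnc2nc(Cl)nc(Cl)c21`, sits at the limit of the test, > 100000 nM

None of these values is a number; each is a limit, the highest concentration the test reports. Compound 2 therefore stands where the other two stand, and nothing separates the three on this read-out. Within the data shown here, the one thing the measurements show is the limit of > 100000 nM in this assay, at which 3 of the 3 values shown sit. All three measured compounds share the same limit. Among the measured compounds shown here, no step between measured compounds can be stated, and no direction of change has been seen in this test.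

Compound 4, `ClCc1ccccc1Cn1cnc2c(Cl)ncnc21`, differs from compound 2 in a single place: hydrogen in place of amino on an aromatic carbon. For the measured compounds named here, with no measured step to lean on, the expectation for this change is a step of no size beyond the usual scatter of repeated measurements, in no particular direction. Compound 4 is therefore expected to remain at the limit of this assay, with an estimate of 150000 nM and a range from 60000 nM to 400000 nM. The estimated step that the limit leaves unreadable from compound 2 to compound 4 is expected to be nothing beyond the scatter.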

Compound 4, concentration lethal to 50% of the cells: > 100000 nM
Compound 4 gave a limit, no number; the forecaster's own chance of this, stated with the estimate: 85%; the middle value lies beyond the limit too.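

Compound 2 and compound 4 both give a limit of the test rather than a number, so no step can be read for hydrogen in place of amino. The compounds shown leave open whether any change to this shared core would give a measurable value in this assay, since all share one ceiling: the limit of > 100000 nM in this assay, at which 4 of the 4 values shown sit.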